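The compounds below may be only part of what the source reports. "The series", "measured", "known", "first", "only" and "open" are said of these compounds alone.

This piece follows a small set of compounds that share one core and differ only in the group attached to an amine nitrogen. All were tested in a functional assay on ECa-109 cells for inhibition, with ECa-109 cell line (Homo sapiens) as the target, read by sulforhodamine B assay; on this read-out higher numbers stand for weaker inhibition and lower numbers for stronger inhibition. Among the compounds with values here, compound 1, `O=C1C=C(Nc2ccc(I)cc2)C(=O)c2c1nc1n2[C@H]2OC[C@@H](O)[C@H]2OC1`, carries a 4-iodophenyl group on that nitrogen, and in this assay compound 1 gives 2300 nM, the only true number among the three values measured so far. Compound 2, `Cc1ccc(NC2=CC(=O)c3c(nc4n3[C@H]3OC[C@@H](O)[C@H]3OC4)C2=O)cc1`, carries a 4-methylphenyl group instead. For compound 2 the assay reports only a limit, > 4000 nM. Compound 3, `O=C1C(NC2CCCCC2)=CC(=O)c2c1nc1n2[C@H]2OC[C@@H](O)[C@H]2OC1`, has a cyclohexyl group on the same nitrogen. For compound 3 the assay again reports only a limit, > 16000 nM. Within the data shown here, the single step between measured compounds that differ in one place, a step that the two limits leave unreadable from compound 2 to compound 3, therefore cannot be sized.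

Compound 4, `CCCc1ccc(NC2=CC(=O)c3nc4n(c3C2=O)[C@H]2OC[C@@H](O)[C@H]2OC4)cc1`, is not yet measured. It differs from compound 1 by propyl in place of iodo on an aromatic carbon. Among the measured compounds shown here, no measured step covers this change. The closest guide is the comparison of compound 1 with its number and compound 2 with its limit; taken together they point toward weaker inhibition when an alkyl chain replaces the iodine. The step expected here is a 2.2-fold higher number from compound 1 to compound 4 (0.34 log units; beyond the scatter). Compound 4 is therefore estimated at 5000 nM, with a likely range from 1500 nM to 16000 nM.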

Compound 4, half-maximal inhibitory concentration: > 4000 nM
Compound 4 was reported as a limit; the forecaster's own chance of this, stated with the estimate: 40%; the middle value does not contradict the limit.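

Replacing the iodo of compound 1 with propyl gives an at least 1.7-fold higher number from compound 1 to compound 4 (0.24 log units; that floor lies within the scatter) in this assay, so this change produces no gain in inhibition, but the floor alone cannot establish a real loss. Within the data shown here, this is the first measured step at this position on the aromatic ring, where the earlier step instead replaced the whole 4-methylphenyl group with cyclohexyl and could not be read. Compound 4 has only a limit and not a number, and it shares that limit with compound 2, so neither the methyl nor the propyl compound gives a true number that could show how chain length matters here: the limit of > 4000 nM in this assay, at which 2 of the 4 values shown sit.

Among these compounds, how far the true number of compound 4 lies beyond its limit stays unknown, so the full size of this step remains open, and compound 1 is still the only compound here with a true number. From the compounds shown here alone, it also remains open how inhibition would respond to a bromo, a methoxy, an amine or a carboxylic acid in place of the iodo on the same aromatic ring.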